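The source may report more compounds than this note shows. Statements on the series, on what has been measured and on what is new or still open speak of the compounds shown alone.

In an ADME assay on microsomes from liver (Homo sapiens) for metabolic stability, read by LC-MS (on this read-out higher numbers stand for a longer-lived compound and lower numbers for a shorter-lived compound), compound 2 `O=C(Nc1ccc(F)c(-c2nc3ncc(-c4cccnc4F)cc3[nH]2)c1)N1CCCC1` gives > 1.5 h, which is a limit of the assay and not a number. Compound 1 `O=C(Nc1ccc(F)c(-c2nc3ncc(-c4ccc(F)cc4)cc3[nH]2)c1)N1CCCC1`, with 4-fluorophenyl in place of 2-fluoropyridin-3-yl, gives 0.203 h.

Compound 3 `O=C(Nc1ccc(F)c(-c2nc3ncc(-c4cc(F)cc(F)c4)cc3[nH]2)c1)N1CCCC1` differs from compound 2 as follows: 3,5-difluorophenyl in place of 2-fluoropyridin-3-yl on an aromatic carbon. The entering 3,5-difluorophenyl, like the 4-fluorophenyl of compound 1, is a six-membered aromatic ring of carbon only.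

For the measured compounds named here, one measured step bears on this change: an at least 7.3-fold higher number from compound 1 to compound 2 (0.86 log units; beyond the scatter), which is beyond the scatter. Going back to a ring of carbon only is therefore expected to undo most of that step, though a single step is thin support. The expected shift is an at least 5.0-fold lower number from compound 2 to compound 3 (0.69 log units; beyond the scatter), a fall beyond the scatter. For compound 3 the estimate is 0.3 h, with an expected range from 0.12 h to 0.8 h.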

Compound 3, half-life: 0.175 h
Estimate against measurement, compound 3: 1.7-fold (0.23 log units) above; the measured number falls inside the stated range.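

In this assay the gain at this position does not extend to another ring of carbon only, with an at least 8.5-fold lower number from compound 2 to compound 3 (0.93 log units; beyond the scatter) on going to 3,5-difluorophenyl. The 4-fluorophenyl and 3,5-difluorophenyl rings read alike, with a 1.2-fold lower number from compound 1 to compound 3 (0.06 log units; within the scatter) between them, so among these three compounds only the 2-fluoropyridin-3-yl stands apart, and a second fluorine on a ring of carbon only brings no separation. Compound 2 sits at a limit of the assay, so the full size of its step to compound 3 stays unknown:  the limit of > 1.5 h in this assay, at which 1 of the 3 values shown sits.

The compounds shown do not separate the ring nitrogen from the fluorine of the 2-fluoropyridin-3-yl, a question that a plain pyridin-3-yl or a pyrimidine ring at this place would address. From the compounds shown here alone, how far this difference would hold with a methoxy or nitrile group on the ring also remains open.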